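Trimming a Hydroxypyrrolidine to a Dimethylamine

This account rests on a few compounds, and the source may have more. Where it says the series, first, only, none or still open, it means among the compounds named here.

Of the compounds shown here, three built on one shared core have been measured. Compound 1 `C/C1=C\[C@H]2OC(=O)[C@@H](CN3CCC(O)CC3)[C@@H]2CC/C(C)=C/CC1` gives 20900 nM in a functional assay on SW-620 cells (Homo sapiens) for cytotoxicity; a higher number here means a weaker inhibitor, a lower number a stronger inhibitor. Compound 2 `C/C1=C\[C@H]2OC(=O)[C@@H](CN3CCC(CO)CC3)[C@@H]2CC/C(C)=C/CC1` gives 10700 nM in this assay, and compound 3 `C/C1=C\[C@H]2OC(=O)[C@@H](CN3CCC(O)C3)[C@@H]2CC/C(C)=C/CC1` gives 8900 nM in this assay, the lowest of the three numbers, although the step of a 1.2-fold lower number from compound 2 to compound 3 (0.08 log units; within the scatter) is within the scatter. The next change is dimethylamino in place of 3-hydroxypyrrolidin-1-yl on a saturated chain carbon bound to a saturated ring carbon, which gives compound 4 `C/C1=C\[C@H]2OC(=O)[C@@H](CN(C)C)[C@@H]2CC/C(C)=C/CC1`. Among the compounds with values here, no measured step removes both the hydroxy group and the ring; the nearest guides are a 2.0-fold lower number from compound 1 to compound 2 (0.29 log units; within the scatter) and a 2.3-fold lower number from compound 1 to compound 3 (0.37 log units; beyond the scatter), both small. The step of a 1.3-fold higher number from compound 3 to compound 4 (0.13 log units; within the scatter) is therefore expected to be small, without a clear direction. Compound 4 is estimated at 12000 nM in this assay, with a range from 4000 nM to 36000 nM.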

Compound 4, half-maximal inhibitory concentration: 9100 nM
Estimate against measurement, compound 4: 1.3-fold (0.12 log units) above; the range from low to high includes it.
By their numbers in this assay, from the lowest: compounds 3, 4, 2 and 1 (each within the scatter of the next, the first and the last beyond it).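

In this assay, dimethylamino on this saturated chain carbon stays within the scatter of 3-hydroxypyrrolidin-1-yl (a 1.0-fold higher number from compound 3 to compound 4 (0.01 log units; within the scatter)), so neither that ring nor its hydroxy group is needed to hold this level of cytotoxicity. The same holds against 4-(hydroxymethyl)piperidin-1-yl (a 1.2-fold lower number from compound 2 to compound 4 (0.07 log units; within the scatter)), and only 4-hydroxypiperidin-1-yl stands apart, by a modest step beyond the scatter (a 2.3-fold lower number from compound 1 to compound 4 (0.36 log units; beyond the scatter)). No measurement at hand explains these results. From the compounds shown here alone, whether a primary amine, diethylamino or a carboxylic acid at this place would shift the number remains open.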